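Working notes: bromobenzyl variant on the shared sulfamate core

The compounds below may be only part of what the source reports. "The series", "measured", "known", "first", "only" and "open" are said of these compounds alone.

Measured so far in an assay on HEK293 cells for inhibition of Steryl-sulfatase (Homo sapiens), tested at 1 uM; a lower number here means a weaker effect, a higher number a stronger effect of the compound at the concentration tested:
compound 1 `CCN(Cc1ccc(Br)cc1)c1cccc(C(=O)N2CCc3ccc(OS(N)(=O)=O)cc3C2)c1` — 84.5%
compound 2 `CCN(Cc1ccncc1)c1cccc(C(=O)N2CCc3ccc(OS(N)(=O)=O)cc3C2)c1` — 52.8%
compound 3 `CC(C)CCN(CCC(C)C)c1cccc(C(=O)N2CCc3ccc(OS(N)(=O)=O)cc3C2)c1` — 75.9%

Compound 3 stands second highest of the three numbers: a number 8.6 percentage points lower from compound 1 to compound 3 (within the scatter), while a number 23.1 percentage points higher from compound 2 to compound 3 (beyond the scatter). Compound 4 `CCN(Cc1cccc(Br)c1)c1cccc(C(=O)N2CCc3ccc(OS(N)(=O)=O)cc3C2)c1` is the next member; the change is (3-bromobenzyl)(ethyl)amino in place of diisopentylamino on an aromatic carbon. Going by the values given here, the step that bears on it is the one between compound 1 and compound 3, which was within the scatter, so (4-bromobenzyl)(ethyl)amino and diisopentylamino gave much the same number. The large drop a number 31.7 percentage points lower from compound 1 to compound 2 (beyond the scatter) came only with a pyridinyl ring, and compound 4 keeps a bromine-bearing carbon ring. Hence the step from compound 3 to compound 4 is expected to be small, a number 4.1 percentage points higher from compound 3 to compound 4 (within the scatter), not beyond the scatter. Compound 4 is estimated at 80%, range 66% to 92%.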

Compound 4, a percentage reported as inhibition, at one concentration (the size of the read-out at that concentration, not a potency): 24.9%
Compound 4: the middle estimate sits 55.1 percentage points above what was measured, and the stated range ends above it.
By their numbers in this assay, from the lowest: compound 4; then compound 2; then compounds 3 and 1 (each within the scatter of the next).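

In this assay, the place of the bromine on the benzyl ring matters: a number 59.6 percentage points lower from compound 1 to compound 4 (beyond the scatter) follows when 3-bromophenyl stands in place of 4-bromophenyl. A bromine-bearing carbon ring therefore does not by itself keep the number, as a number 27.9 percentage points lower from compound 2 to compound 4 (beyond the scatter) comes with 3-bromophenyl in place of pyridin-4-yl, and a number 51 percentage points lower from compound 3 to compound 4 (beyond the scatter) with (3-bromobenzyl)(ethyl)amino in place of diisopentylamino. Nothing available accounts for this loss.

Open, as far as these compounds go, is whether the loss follows the bromine itself or any group at that place. An unsubstituted benzyl group or a 3-chlorobenzyl group would separate these readings.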